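The source may report more compounds than this note shows. Statements on the series, on what has been measured and on what is new or still open speak of the compounds shown alone.

In a functional assay on DU-145 cells (Homo sapiens) for inhibition, read by trypan blue exclusion, with a stated time of 96 h (on this read-out lower numbers stand for stronger inhibition of growth and higher numbers for weaker inhibition of growth), compound 1 `Cc1ccc(S(=O)(=O)/C(=C/c2ccc(O)c([N+](=O)[O-])c2)C(=O)c2ccc(Cl)cc2)cc1` gives 25000 nM and compound 2 `COc1ccccc1/C=C(\C(=O)c1ccc(Cl)cc1)S(=O)(=O)c1ccc(C)cc1` gives 1000 nM. Compound 3 `Cc1ccc(S(=O)(=O)/C(=C/c2ccc(N(C)C)cc2)C(=O)c2ccc(Cl)cc2)cc1` gives only a limit of the assay, > 100000 nM, so it sits at the weak end of the three and has no exact number.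

Compound 4 `Cc1ccc(S(=O)(=O)/C(=C/c2cc(C)ccc2C)C(=O)c2ccc(Cl)cc2)cc1` carries 2,5-dimethylphenyl in place of 4-(dimethylamino)phenyl on a double-bonded chain carbon bound to a double-bonded chain carbon. Going by the values given here, no measured step makes this exact exchange, but three steps change the group at the same place. The data show an at least 100-fold higher number from compound 2 to compound 3 (2.00 log units; beyond the scatter) and an at least 4.0-fold higher number from compound 1 to compound 3 (0.60 log units; beyond the scatter), while a 25-fold lower number from compound 1 to compound 2 (1.40 log units; beyond the scatter) shows how widely the number moves with this group alone. Both measured compounds lie clearly on the stronger side of the limit. Compound 2, at 1000 nM, is taken as the nearer guide by the name of its group.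

A sizeable move toward stronger inhibition is therefore expected, an at least 20-fold lower number from compound 3 to compound 4 (1.30 log units; beyond the scatter). For compound 4 the estimated value is 5000 nM, with an expected range of 800 nM to 30000 nM.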

Compound 4, concentration for 50% growth inhibition: 1000 nM
The estimate for compound 4 lay 5.0-fold (0.70 log units) above the measured number, within the range that was stated.
By their numbers in this assay, from the lowest: compounds 2 and 4 (each within the scatter of the next); then compound 1. At a limit, above all of these: compound 3.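

In this assay, a group of carbon only proves sufficient at this place on a double-bonded chain carbon bound to a double-bonded chain carbon: 2,5-dimethylphenyl gives an at least 100-fold lower number from compound 3 to compound 4 (2.00 log units; beyond the scatter) and a 25-fold lower number from compound 1 to compound 4 (1.40 log units; beyond the scatter). It also gives no change at the digits printed from compound 2 to compound 4 (within the scatter), so the level of 2-methoxyphenyl is reached by a group with no hydrogen-bond acceptor. Compound 3 stays a limit of the assay, so its step gives a minimum size and not an exact one: the limit of > 100000 nM in this assay, at which 1 of the 4 values shown sits.

On these data alone, whether an unsubstituted phenyl, a phenyl with a single methyl, or a pyridyl ring would hold this level remains open. As far as these compounds go, the rest of the shared core is the same in all four compounds, so the effect of this exchange alongside any other group there, such as an amine in place of the chlorine, also remains open.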